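The source may report more compounds than this note shows. Statements on the series, on what has been measured and on what is new or still open speak of the compounds shown alone.

Measured compounds:
compound 1 `Cc1cc(C)cc(COc2ccc(-c3cc(CN4CCN(Cc5ccc(C(F)(F)F)cc5)CC4)no3)cc2)c1` — in a functional assay on MCF7 cells (Homo sapiens) for antiproliferative activity, read by sulforhodamine B assay, with a stated time of 72 h (a lower number here means a stronger inhibitor, a higher number a weaker inhibitor), compound 1 gives 1600 nM
compound 2 `COc1cc(COc2ccc(-c3cc(CN4CCN(Cc5ccc(C(F)(F)F)cc5)CC4)no3)cc2)cc(OC)c1` — in this assay compound 2 gives 100 nM

Within the data shown here, compound 2 holds the lowest number of the two measured in this assay; the one step recorded, a 16-fold lower number from compound 1 to compound 2 (1.20 log units; beyond the scatter), separates it from compound 1 and lies beyond the scatter.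

Compound 3 `COc1cc(COc2ccc(-c3cc(CN4CCN(Cc5ccc(C(F)(F)F)cc5)CC4)no3)cc2)cc(OC)c1OC` is the next member. Compared with compound 2, the change is methoxy in place of hydrogen on an aromatic carbon. Among the measured compounds shown here, no measured step covers the addition of a third methoxy to this ring: the only step in hand, a 16-fold lower number from compound 1 to compound 2 (1.20 log units; beyond the scatter), exchanges methyl for methoxy at the two existing positions, so it shows that the nature of the groups on this phenyl matters strongly for this assay, but it does not tell how a further methoxy acts. With that in mind, compound 3 is expected to stay close to compound 2, with a modest step of a 1.4-fold lower number from compound 2 to compound 3 (0.15 log units; within the scatter) that may well sit inside the scatter. The estimate for compound 3 in this assay is 70 nM, with a range from 20 nM to 250 nM.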

Compound 3, half-maximal inhibitory concentration: 1800 nM
Estimate against measurement, compound 3: 26-fold (1.41 log units) below; the measured number lies above the stated range.
By their numbers in this assay, from the lowest: compound 2; then compounds 1 and 3 (each within the scatter of the next).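

In this assay the aromatic carbon ortho to two methoxy groups and para to a large group proves far from neutral: filling it with methoxy gives an 18-fold higher number from compound 2 to compound 3 (1.26 log units; beyond the scatter), a step as large as the one that first favoured the 3,5-dimethoxyphenyl group, a 16-fold lower number from compound 1 to compound 2 (1.20 log units; beyond the scatter). The 3,4,5-trimethoxyphenyl group therefore does not extend the advantage of the 3,5-dimethoxyphenyl group but cancels it, with a 1.1-fold higher number from compound 1 to compound 3 (0.05 log units; within the scatter) placing compound 3 level with compound 1, so that among these three only compound 2 stands apart, its steps to both others being beyond the scatter. Nothing available accounts for this reversal.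

Open, as far as these compounds go, is whether the loss belongs to methoxy itself or to any group on this carbon, a question that fluorine, a hydroxyl or an amine there, with the two existing methoxy groups kept, would address. Also open, from the compounds shown here alone, is how a single methoxy on this carbon behaves when the two existing methoxy groups are replaced by hydrogen, and whether a longer chain such as ethoxy there follows compound 3.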